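The source may report more compounds than this note shows. Statements on the series, on what has been measured and on what is new or still open speak of the compounds shown alone.

In a functional assay on MDA-MB-231 cells (Homo sapiens) for antiproliferative activity, with a stated time of 5 days (on this read-out higher numbers stand for weaker inhibition and lower numbers for stronger inhibition), compound 3 `O=C1C=CC2(C=C1)OCC(=O)N2c1nc(-c2cccc3ccccc23)nn1-c1ccccc1` gives 50 nM, within the scatter of both compound 2 `O=C1C=CC2(C=C1)OCC(=O)N2c1nc(-c2ccc(F)c3ccccc23)nn1-c1ccccc1` at 80 nM and compound 1 `Cc1ccc(-n2nc(-c3ccc4ccccc4c3)nc2N2C(=O)COC23C=CC(=O)C=C3)cc1` at 30 nM. Compound 4 `O=C1C=CC2(C=C1)OCC(=O)N2c1nc(-c2ccc3ccccc3c2)nn1-c1ccccc1` carries naphthalen-2-yl in place of naphthalen-1-yl on an aromatic carbon of the five-membered aromatic ring with 3 nitrogen: naphthalen-2-yl in place of naphthalen-1-yl on an aromatic carbon. Among the measured compounds shown here, the only measured step, a 1.6-fold lower number from compound 2 to compound 3 (0.20 log units; within the scatter), is hydrogen in place of fluoro and lies within the scatter, so it says little about this change. Compound 1 also carries naphthalen-2-yl and gives 30 nM, but it differs from compound 4 elsewhere too, so it offers only a weak lean towards a lower number. The estimated step is a 1.4-fold lower number from compound 3 to compound 4 (0.15 log units; within the scatter) in this assay, with none expected beyond the scatter. Compound 4 is expected at 35 nM, with an estimated range of 15 nM to 90 nM.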

Compound 4, half-maximal inhibitory concentration: 70 nM
Beside the measured number, compound 4's estimate is 2.0-fold (0.30 log units) below it; measured number inside the range.
By their numbers in this assay, from the lowest: compounds 1, 3, 4 and 2 (each within the scatter of the next, the first and the last beyond it).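

In this assay, the switch of attachment gives a 1.4-fold higher number from compound 3 to compound 4 (0.15 log units; within the scatter), and a 1.1-fold lower number from compound 2 to compound 4 (0.06 log units; within the scatter) is also within the scatter, so on this aromatic carbon neither naphthalen-1-yl, naphthalen-2-yl nor 4-fluoronaphthalen-1-yl separates from the others. Among the compounds shown here, the only step here beyond the scatter is a modest one, a 2.3-fold higher number from compound 1 to compound 4 (0.37 log units; beyond the scatter), with hydrogen in place of methyl. No measured evidence bears on the cause of these steps.

From the compounds shown here alone, whether the methyl step carries over to the naphthalen-1-yl compounds remains open. So does the effect of an amine or a carboxylic acid on the naphthalene.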